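This account rests on a few compounds, and the source may have more. Where it says the series, first, only, none or still open, it means among the compounds named here.

The series shares one core, seen in compound 1 `COc1cc(NC(C)CCCNC(=O)Nc2cccc(F)c2)c2ncccc2c1`, compound 2 `COc1cc(NC(C)CCCNC(=O)Nc2ccc(Br)cc2)c2ncccc2c1` and compound 3 `COc1cc(NC(C)CCCNC(=O)Nc2ccc(C(F)(F)F)cc2)c2ncccc2c1`, and differs only in the group on the amide-type nitrogen. In a functional assay on CCRF-CEM cells (Homo sapiens) for inhibition, read by MTT assay, with a stated time of 72 h (on this read-out higher numbers stand for weaker inhibition and lower numbers for stronger inhibition), compound 1 gives 21000 nM, compound 2 gives 23000 nM and compound 3 gives 14000 nM. On these numbers compound 2 stands at the top, yet both steps away from it lie within the scatter: a 1.1-fold higher number from compound 1 to compound 2 (0.04 log units; within the scatter) and a 1.6-fold lower number from compound 2 to compound 3 (0.22 log units; within the scatter). Compound 4 `COc1cc(NC(C)CCCNC(=O)Nc2ccc(Cl)cc2)c2ncccc2c1` follows as the next step from compound 2: chloro in place of bromo on an aromatic carbon. The step bearing most on it is a 1.6-fold lower number from compound 2 to compound 3 (0.22 log units; within the scatter), another swap on an aromatic carbon, and a 1.5-fold lower number from compound 1 to compound 3 (0.18 log units; within the scatter) was likewise within the scatter. No step beyond the scatter is therefore expected in this assay. Compound 4 is estimated at 21000 nM, with a range of 10000 nM to 42000 nM. The expected step is a 1.1-fold lower number from compound 2 to compound 4 (0.04 log units; within the scatter).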

Compound 4, half-maximal inhibitory concentration: 24000 nM
Compound 4: middle estimate off by 1.1-fold (0.06 log units), on the low side; measured number inside the range.
By their numbers in this assay, from the lowest: compounds 3, 1, 2 and 4 (each within the scatter of the next).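

Chloro in place of bromo on this aromatic carbon, para to a large group, gives no readable difference in this assay: a 1.0-fold higher number from compound 2 to compound 4 (0.02 log units; within the scatter). The new compound also stays within the scatter of the other two aryl groups, with a 1.7-fold higher number from compound 3 to compound 4 (0.23 log units; within the scatter) and a 1.1-fold higher number from compound 1 to compound 4 (0.06 log units; within the scatter), so all four aryl ureas remain unseparated. No measured evidence bears on this result.

From the compounds shown here alone, whether an amine or a carboxylic acid at this aromatic carbon would give a step beyond the scatter remains open. So does the effect of a longer chain between the shared core and the urea.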